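The source may hold more compounds than are shown below. What is called first, only, known or untested is meant among the compounds shown, and "the series" means these compounds.

Three compounds have so far been run through a functional assay on NCI/ADR-RES cells (Homo sapiens) for inhibition, read by spectrophotometry and sulforhodamine B assay, with a stated time of 48 h; on this read-out higher numbers stand for weaker inhibition of growth and lower numbers for stronger inhibition of growth. Compound 1 `O=C1CS/C(=N/N=C/c2c[nH]c3ccccc23)N1c1cccc2ccccc12` gives 38600 nM. Compound 3 `O=C1CS/C(=N/N=C/c2c[nH]c3ccc(Br)cc23)N1c1cccc2ccccc12` gives 12400 nM, and compound 2 `S=C(N/N=C/c1c[nH]c2ccc(Br)cc12)Nc1cccc2ccccc12` gives 6180 nM, the lowest of the three numbers. Compounds 3 and 1 differ in one place, (hydrogen in place of bromo on an aromatic carbon), and that change gave a 3.1-fold higher number from compound 3 to compound 1 (0.49 log units; beyond the scatter). How the core of compound 2 differs from the core of compound 3 is not broken down here. Compound 4 `S=C(N/N=C/c1c[nH]c2ccccc12)Nc1cccc2ccccc12` has not yet been measured; it differs from compound 2 by hydrogen in place of bromo on an aromatic carbon, the same change as from compound 3 to compound 1, on the same kind of position. Because the earlier step gave a 3.1-fold higher number from compound 3 to compound 1 (0.49 log units; beyond the scatter), a step of about the same size is expected here, a 3.1-fold higher number from compound 2 to compound 4 (0.49 log units; beyond the scatter). On that basis compound 4 is estimated at 19000 nM, expected to fall between 6500 nM and 55000 nM.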

Compound 4, concentration for 50% growth inhibition: 6480 nM
Compound 4: middle estimate off by 2.9-fold (0.47 log units), on the high side, and the stated range ends above it.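

In this assay, replacing bromo with hydrogen on the core of compound 2 gives a 1.0-fold higher number from compound 2 to compound 4 (0.02 log units; within the scatter), so on this core the bromo shows no measurable effect on growth inhibition. Two pairs cannot explain this difference or predict the size of the step on a third core. They do show that the step measured on one core did not carry over at the same size to the other: the same change on two cores in this assay, a 3.1-fold higher number (0.49 log units; beyond the scatter) from compound 3 to compound 1 and a 1.0-fold higher number (0.02 log units; within the scatter) from compound 2 to compound 4, 3.0-fold (0.47 log units) apart, beyond the scatter of two such steps.

The compounds shown carry only bromo or hydrogen at this place on the ring. From the compounds shown here alone, it remains open whether a chloro group, a methoxy group or an amine there would behave as on the core of compound 3 or as on the core of compound 2.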